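Compound 2 trades its fluoro group

A few compounds are considered here, and "the series" means these few. Any claim that something is new, unique, unknown or untested is made for them only; others in the source may bear on it.

- compound 1 `C[C@H](Nc1ccc(C#N)n(C)c1=O)c1cc2cc(Cl)c(OCC3CC3)cc2[nH]c1=O`: 530 nM
- compound 2 `C[C@H](Nc1ccc(C#N)n(C)c1=O)c1cc2cc(Cl)c(F)cc2[nH]c1=O`: 18000 nM
- compound 3 `Cn1c(C(F)(F)F)ccc(NCc2cc3cc(Cl)ccc3[nH]c2=O)c1=O`: < 100 nM (a limit of the assay, not a number)

In a physicochemical assay for solubility (a higher number here means a more soluble compound, a lower number a less soluble compound), compound 2 holds the higher of the two real numbers, at 18000 nM. For compound 3 there is only (the limit of < 100 nM in this assay, at which 1 of the 3 values shown sits).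

The next compound is compound 4 `C[C@H](Nc1ccc(C#N)n(C)c1=O)c1cc2cc(Cl)c(O[C@H](C)c3ccccn3)cc2[nH]c1=O`. It differs from compound 2 at one place: 1-(pyridin-2-yl)ethoxy in place of fluoro on an aromatic carbon. In words, 1-(pyridin-2-yl)ethoxy stands in place of fluoro on an aromatic carbon.

Among the compounds with values here, one measured step bears on this, and it runs the opposite way. With fluoro in place of cyclopropylmethoxy, the change is a 34-fold higher number from compound 1 to compound 2 (1.53 log units; beyond the scatter). Leaving fluoro for another group joined through oxygen should therefore reverse much of that large step, so a clearly lower number is expected in this assay. This expectation rests on that single pair alone, so the range stays wide. The expected change is a 26-fold lower number from compound 2 to compound 4 (1.41 log units; beyond the scatter). Compound 4 is estimated at 700 nM, with an expected range of 150 nM to 4000 nM.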

Compound 4, solubility: 1600 nM
Beside the measured number, compound 4's estimate is 2.3-fold (0.36 log units) below it; measured number inside the range.
By their numbers in this assay, from the lowest: compound 1; then compound 4; then compound 2. At a limit, below all of these: compound 3.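

In this assay, putting 1-(pyridin-2-yl)ethoxy in place of fluoro on this aromatic carbon, ortho to a chloro group, gives an 11-fold lower number from compound 2 to compound 4 (1.05 log units; beyond the scatter) and so confirms, with a second oxygen-linked group, that compound 2 keeps the highest number of those with real values. Changing only what sits on the oxygen, 1-(pyridin-2-yl)ethyl in place of cyclopropylmethyl, gives a 3.0-fold higher number from compound 1 to compound 4 (0.48 log units; beyond the scatter), a modest step, so the number depends on that group and not only on the oxygen link. Nothing measured here bears on why these numbers move.

From the compounds shown here alone, a plain 1-phenylethoxy group would show whether the ring nitrogen of compound 4 matters, and the opposite stereocentre of the same group remains open too. Also open, going by these compounds, is whether an amine or a carboxylic acid at this position would bring the number back towards that of compound 2.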